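Furan-3-yl for pyridin-3-yl on the shared core

A few compounds are considered here, and "the series" means these few. Any claim that something is new, unique, unknown or untested is made for them only; others in the source may bear on it.

In a functional assay on PC-3 cells (Homo sapiens) for antiproliferative activity, read by CCK-8 assay, with a stated time of 6 days (on this read-out higher numbers stand for weaker inhibition and lower numbers for stronger inhibition), compound 1 `CCN(c1ccc(C#N)c(Cl)c1)c1cc(C2=CCCCC2)ccc1C` is recorded as "not determined" (no result reported), so it offers no number. Compound 2 `CCN(c1ccc(C#N)c(Cl)c1)c1cc(-n2cccn2)ccc1C` gives 15700 nM. Compound 3 `CCN(c1ccc(C#N)c(Cl)c1)c1cc(-c2cccnc2)ccc1C` gives 11000 nM, within the scatter of compound 2. Compound 4 `CCN(c1ccc(C#N)c(Cl)c1)c1cc(-c2ccoc2)ccc1C` is next, with this change: furan-3-yl in place of pyridin-3-yl on an aromatic carbon. In words, furan-3-yl stands in place of pyridin-3-yl on an aromatic carbon. Going by the values given here, the only measured step that bears on it is a 1.4-fold lower number from compound 2 to compound 3 (0.15 log units; within the scatter), also an exchange of one aromatic ring for another, and it stayed within the scatter. The expected step in this assay is therefore none beyond the scatter, estimated as a 1.1-fold higher number from compound 3 to compound 4 (0.04 log units; within the scatter). For compound 4 the estimated value is 12000 nM, with an expected range of 5500 nM to 24000 nM.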

Compound 4, half-maximal inhibitory concentration: > 30000 nM
Compound 4 ended at the assay's limit (the forecaster's own chance of this, stated with the estimate: 15%); middle value at least 2.5-fold (0.39 log units) from the limit.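

In this assay compound 4 stands at a limit, not at a number: the limit of > 30000 nM in this assay, at which 1 of the 4 values shown sits.
The exchange of pyridin-3-yl for furan-3-yl gives an at least 2.7-fold higher number from compound 3 to compound 4 (0.43 log units; beyond the scatter), so this position does respond to the choice of aromatic ring, which the earlier step, a 1.4-fold lower number from compound 2 to compound 3 (0.15 log units; within the scatter), did not show. Against 1H-pyrazol-1-yl the reading is less firm: an at least 1.9-fold higher number from compound 2 to compound 4 (0.28 log units; that floor lies within the scatter).

From the compounds shown here alone, how far compound 4 lies past the limit stays open. Also open, going by these compounds, is how an amine or a carboxylic acid at this position would read.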